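A Chlorine Moved to the Other Ring

The compounds below may be only part of what the source reports. "The series", "measured", "known", "first", "only" and "open" are said of these compounds alone.

Among the compounds with values here, compound 1 `O=C(c1ccc(N2CCCC2)cc1)N1CCCCc2ccccc21` in an assay on HeLa cells for binding affinity to Vasopressin V2 receptor (Homo sapiens) (on this read-out higher numbers stand for weaker inhibition and lower numbers for stronger inhibition), gives 1000 nM, the highest of the two numbers measured; its only neighbour is compound 2 `O=C(c1ccc(N2CCCC2)cc1Cl)N1CCCCc2ccccc21`, which in this assay gives 9 nM. The change a 110-fold lower number from compound 1 to compound 2 (2.05 log units; beyond the scatter) is a chloro in place of hydrogen on an aromatic carbon of the part carrying the pyrrolidine. Compound 3 `O=C(c1ccc(N2CCCC2)cc1)N1CCCCc2cc(Cl)ccc21` differs from compound 1 by chloro in place of hydrogen on an aromatic carbon, the same kind of change but on the other ring system. Within the data shown here, only the step from compound 1 to compound 2 bears on it, and it sits in a different place, so a smaller shift is expected, as a 2.0-fold lower number from compound 1 to compound 3 (0.30 log units; within the scatter). Compound 3 is therefore estimated at 500 nM, within 100 nM to 3000 nM.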

Compound 3, half-maximal inhibitory concentration: 210 nM
Estimate against measurement, compound 3: 2.4-fold (0.38 log units) above; low and high end bracket the measured number.
By their numbers in this assay, from the lowest: compound 2; then compound 3; then compound 1.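

On the other ring too, chloro in place of hydrogen lowers the number in this assay, with a 4.8-fold lower number from compound 1 to compound 3 (0.68 log units; beyond the scatter). This aromatic carbon, on a six-membered ring that is part of a fused system of two rings, therefore responds to the change, though more modestly than the ring carrying the pyrrolidine, which showed a 110-fold lower number from compound 1 to compound 2 (2.05 log units; beyond the scatter). No measurement here accounts for the difference between the two places. On these data alone, whether fluoro or methoxy on this same carbon would shift the number as chloro does remains open. So does what chloro on both rings together would give.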